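Phenyl to benzyl on the ring nitrogen: working notes

The source may hold more compounds than are shown below. What is called first, only, known or untested is meant among the compounds shown, and "the series" means these compounds.

Measured in a functional assay on HT-29 cells (Homo sapiens) for antiproliferative activity, read by MTT assay, with a stated time of 48 h; on this read-out higher numbers stand for weaker inhibition and lower numbers for stronger inhibition:
compound 1 `COc1cc(/C=N/c2c(C#N)ncn2-c2ccc(F)cc2)cc(OC)c1OC` gives 13700 nM
compound 2 `COc1ccc(OC)c(/C=N/c2c(C#N)ncn2-c2ccc(F)cc2)c1` gives 16300 nM
compound 3 `COc1cc(/C=N/c2c(C#N)ncn2Cc2ccc(F)cc2)cc(OC)c1OC` gives 16500 nM

Compound 1 and compound 2 share the nitrile-bearing core but differ in the substituted aryl part of the imine; the difference between the two cores is not broken down here. Their values in this assay sit within the scatter of each other, so no order between them is claimed.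

Compound 3 is compound 1 with 4-fluorobenzyl in place of 4-fluorophenyl on an aromatic nitrogen. The step of a 1.2-fold higher number from compound 1 to compound 3 (0.08 log units; within the scatter) is within the scatter, so the change is read as neutral on this read-out.

Compound 4 `COc1ccc(OC)c(/C=N/c2c(C#N)ncn2Cc2ccc(F)cc2)c1` is not yet measured. It stands to compound 2 as compound 3 stands to compound 1: 4-fluorobenzyl in place of 4-fluorophenyl on an aromatic nitrogen. The two place lines match word for word, so this is the same change made once more.

Given that the only measured instance of this change, the step from compound 1 to compound 3, is within the scatter, a comparable step a 1.2-fold higher number from compound 2 to compound 4 (0.07 log units; within the scatter) is expected for compound 4. Compound 4 is therefore estimated at 19000 nM in this assay, with a range of 9000 nM to 40000 nM.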

Compound 4, half-maximal inhibitory concentration: 22400 nM
Compound 4: the middle estimate sits 1.2-fold (0.07 log units) below what was measured; low and high end bracket the measured number.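

On the core of compound 2, 4-fluorobenzyl in place of 4-fluorophenyl on the aromatic nitrogen gives, in this assay, a 1.4-fold higher number from compound 2 to compound 4 (0.14 log units; within the scatter), so this step too is read as neutral on this read-out. Set beside the step on the core of compound 1, the change carries over from one core to the other without a difference that can be read: the same change on two cores in this assay, a 1.2-fold higher number (0.08 log units; within the scatter) from compound 1 to compound 3 and a 1.4-fold higher number (0.14 log units; within the scatter) from compound 2 to compound 4, 1.1-fold (0.06 log units) apart, within the scatter of two such steps. This supports a neutral swap on these two cores only; since each step lies within the scatter, no direction is claimed for the change, and nothing follows for cores outside these four compounds.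

The compounds shown leave open whether the aromatic nitrogen tolerates anything other than these two fluorinated aryl groups, such as a longer chain carrying the 4-fluorophenyl ring, or a chain ending in an amine or a carboxylic acid. They also leave open whether the same swap stays neutral when the nitrile is replaced by an amide.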